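The source may report more compounds than this note shows. Statements on the series, on what has been measured and on what is new or still open speak of the compounds shown alone.

Working notes on the series. Three compounds share an aromatic amide carrying an amino-substituted phenyl, attached through a benzylic or similar linker to a substituted core. Compound 1 `CN1CCN(c2nc(Cl)nc3c2ncn3Cc2ccc(C(=O)Nc3ccccc3N)cc2)CC1` gives 13.5% in a functional assay on NCI-H460 cells (Homo sapiens) for antiproliferative activity, read by CCK-8 assay, with a stated time of 72 h, tested at 2 uM; on this read-out higher numbers stand for a stronger effect at the one concentration tested and lower numbers for a weaker effect. Compound 2 `CC(C)n1cnc2c(Nc3cccc(Cl)c3)nc(NCOCc3ccc(C(=O)Nc4ccccc4N)cc3)nc21` gives 28.9% in this assay. Compound 3 `Nc1ccccc1NC(=O)/C=C/c1ccc(Cn2cnc3c(Nc4cccc(Cl)c4)nc(Cl)nc32)cc1` gives 7.11% in this assay, the lowest of the three numbers; the number of compound 1 lies within the usual scatter of that of compound 3, so no order between those two can be read, while compound 2 stands beyond the scatter above compound 3.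

Compound 4 `Nc1ccccc1NC(=O)/C=C/c1ccc(Cn2cnc3c(NC4CCCCC4)nc(Cl)nc32)cc1` has not yet been measured in this assay. It differs from compound 3 in a single change: cyclohexyl in place of 3-chlorophenyl on a nitrogen on an aromatic ring. Going by the values given here, no measured pair in the set carries this change, so its size here is unknown. Since compound 3 sits at 7.11% and the measured numbers around it are all modest, the expected step is small, a number 2.9 percentage points higher from compound 3 to compound 4 (within the scatter), with no direction that should exceed the scatter. Compound 4 is estimated at 10% in this assay, with a range from 0% to 25%.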

Compound 4, a percentage reported as inhibition, at one concentration (the size of the read-out at that concentration, not a potency): 8.09%
Compound 4: middle estimate off by 1.9 percentage points, on the high side, within the range that was stated.
By their numbers in this assay, from the lowest: compounds 3, 4 and 1 (each within the scatter of the next); then compound 2.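

At the nitrogen on an aromatic ring, this pair gives the series its first single-change comparison: in this assay, cyclohexyl in place of 3-chlorophenyl gives a number 1 percentage points higher from compound 3 to compound 4 (within the scatter) at the one concentration tested. At this position, therefore, the read-out does not separate a chlorine-bearing aromatic ring from a non-aromatic ring of carbon only, on this background and with both values near the low end of the numbers shown so far. No measurement available here bears on why the two groups read alike.

Steps from compound 1 or compound 2 to compound 3 or compound 4 cannot be read, since these compounds differ in more than one place, so the part played by the linker and the other substituents on the shared core remains unresolved. On these data alone, it also remains open whether a different group on this nitrogen, such as an unsubstituted phenyl, a morpholinoethyl chain or a short chain ending in a carboxylic acid, would move the number beyond the scatter.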